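A few compounds are considered here, and "the series" means these few. Any claim that something is new, unique, unknown or untested is made for them only; others in the source may bear on it.

Measured compounds:

Compound 1 `COc1cccc2[nH]cc(C3(c4c[nH]c5cccc(OC)c45)C(=O)Nc4ccccc43)c12` gives 15300 nM in a functional assay on A549 cells (Homo sapiens) for cytotoxicity, read by MTT assay, with a stated time of 48 h; on this read-out lower numbers stand for stronger inhibition and higher numbers for weaker inhibition.
Compound 2 `O=C1Nc2ccccc2C1(c1c[nH]c2ccc(Cl)cc12)c1c[nH]c2ccc(Cl)cc12` gives 8300 nM in this assay.
Compound 3 `COc1cccc2[nH]cc(C3(c4c[nH]c5cccc(OC)c45)C(=O)Nc4ccc(F)cc43)c12` gives 7800 nM in this assay.

Compound 3 is made from compound 1 by one change: fluoro in place of hydrogen on an aromatic carbon. That change produced a step of a 2.0-fold lower number from compound 1 to compound 3 (0.29 log units; within the scatter). Compound 2 has a different core; the difference between the two cores is not broken down here. Compound 4 `O=C1Nc2ccc(F)cc2C1(c1c[nH]c2ccc(Cl)cc12)c1c[nH]c2ccc(Cl)cc12` is not yet measured in this assay. It is made from compound 2 by fluoro in place of hydrogen on an aromatic carbon, and the surroundings of the place are described in the same words as for the step from compound 1 to compound 3, so this is the same change. The same small step is expected from compound 2 to compound 4, a 1.5-fold lower number from compound 2 to compound 4 (0.18 log units; within the scatter), resting on the step seen from compound 1 to compound 3 of a 2.0-fold lower number from compound 1 to compound 3 (0.29 log units; within the scatter). Compound 4 is therefore estimated at 5500 nM, between 2500 nM and 12000 nM.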

Compound 4, half-maximal inhibitory concentration: 12100 nM
Compound 4: the middle estimate sits 2.2-fold (0.34 log units) below what was measured; measured number above the stated range.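

In this assay, putting fluoro in place of hydrogen on the aromatic carbon gives a 1.5-fold higher number from compound 2 to compound 4 (0.16 log units; within the scatter). Each step alone is small, but set side by side they show that this change does not carry over unaltered between these two cores: the same change on two cores in this assay, a 2.0-fold lower number (0.29 log units; within the scatter) from compound 1 to compound 3 and a 1.5-fold higher number (0.16 log units; within the scatter) from compound 2 to compound 4, 2.9-fold (0.46 log units) apart, beyond the scatter of two such steps. Going by these compounds alone, this does not show why the cores differ, and with only one pair on each core it gives no rule for any further core.

The compounds shown carry only hydrogen or fluoro at this place, so it remains open how an amine or a carboxylic acid there would read. From the compounds shown here alone, it also remains open whether such a group would give matching steps on the two cores.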